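Aryl ketone chain in place of the dichlorophenoxy ether

The source may hold more compounds than are shown below. What is called first, only, known or untested is meant among the compounds shown, and "the series" means these compounds.

Among the measured compounds shown here, compound 3 `CC(C)C[C@H](N)c1cc(C(F)(F)F)ccc1N1CCN(C(=O)COc2cccc(Cl)c2Cl)CC1` gives 2500 nM in an assay on HEK293 cells for displacement of a labelled ligand from Melanocortin receptor 4 (Homo sapiens) (a higher number here means a weaker inhibitor, a lower number a stronger inhibitor), the second highest of the three numbers known. Its nearest neighbour is compound 1 `COc1ccc(OCC(=O)N2CCN(c3ccc(C(F)(F)F)cc3[C@@H](N)CC(C)C)CC2)cc1` at 3800 nM, and the two lie within the scatter of each other, as a 1.5-fold lower number from compound 1 to compound 3 (0.18 log units; within the scatter) shows. Far below both stands compound 2 `Cc1cc(Cl)ccc1CC(C)C(=O)N1CCN(c2ccc(C(F)(F)F)cc2[C@@H](N)CC(C)C)CC1` at 38 nM; the gap a 66-fold higher number from compound 2 to compound 3 (1.82 log units; beyond the scatter) is large.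

Compound 4 `CC(C)C[C@H](N)c1cc(C(F)(F)F)ccc1N1CCN(C(=O)CC(C)C(=O)c2ccc(Cl)cc2)CC1` is not yet measured. It differs from compound 3 in one place: 1-((4-chlorophenyl)carbonyl)ethyl in place of 2,3-dichlorophenoxy on a saturated chain carbon bound to a carbonyl carbon. The step that bears on this change is a 100-fold lower number from compound 1 to compound 2 (2.00 log units; beyond the scatter), where an oxygen-linked aryl group on the carbonyl carbon gave way to a branched carbon chain carrying an aromatic ring; compound 4 likewise exchanges an aryloxy link for a branched carbon chain with an aromatic ring, though here as an aryl ketone rather than a benzyl group. For the measured compounds named here, a large lowering is therefore expected, and compound 4 is estimated at 150 nM, between 40 nM and 600 nM, a step of a 17-fold lower number from compound 3 to compound 4 (1.22 log units; beyond the scatter), likely not reaching the level of compound 2, since the entering group is not the one seen there and no measured step covers it.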

Compound 4, inhibition constant: 1100 nM
Beside the measured number, compound 4's estimate is 7.3-fold (0.87 log units) below it; the measured number lies above the stated range.
By their numbers in this assay, from the lowest: compound 2; then compound 4; then compounds 3 and 1 (each within the scatter of the next).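

In this assay, 1-((4-chlorophenyl)carbonyl)ethyl on a saturated chain carbon bound to a carbonyl carbon improves on both aryloxy groups only modestly, with a 2.3-fold lower number from compound 3 to compound 4 (0.36 log units; beyond the scatter) and a 3.5-fold lower number from compound 1 to compound 4 (0.54 log units; beyond the scatter) on the two sides. A carbon chain carrying an aromatic ring is thus not enough on its own to reach the level of compound 2, as a 29-fold higher number from compound 2 to compound 4 (1.46 log units; beyond the scatter) separates the ketone chain from 1-(4-chloro-2-methylbenzyl)ethyl. No measurement is available to explain this gap between the two chains.

From the compounds shown here alone, it remains open whether a hydroxyl group or a plain methylene in place of the ketone carbonyl would close that gap. Equally open, going by these compounds, is what a methyl group on the aromatic ring of the ketone chain would do.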